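Swapping Trifluoromethyl for Methoxy in a Cytotoxicity Series

The source may report more compounds than this note shows. Statements on the series, on what has been measured and on what is new or still open speak of the compounds shown alone.

Compound 1 `Cc1cc(-c2cccc(C(F)(F)F)c2)cc(C)c1Nc1ccnc(Nc2ccc(C#N)cc2)n1` gives 4030 nM in an ADME assay on MT4 cells (Homo sapiens) for cytotoxicity, read by MTT assay, with a stated time of 4 days (on this read-out higher numbers stand for lower toxicity in this test and lower numbers for higher toxicity in this test), the second highest of three numbers, though all three sit within the scatter of one another. Compound 2 `Cc1cc(-c2cc(Cl)cc(Cl)c2)cc(C)c1Nc1ccnc(Nc2ccc(C#N)cc2)n1` gives 4290 nM and compound 3 `Cc1cc(-c2ccccc2Cl)cc(C)c1Nc1ccnc(Nc2ccc(C#N)cc2)n1` gives 3990 nM in this assay. The steps of a 1.1-fold higher number from compound 1 to compound 2 (0.03 log units; within the scatter), a 1.0-fold lower number from compound 1 to compound 3 (0.00 log units; within the scatter) and a 1.1-fold lower number from compound 2 to compound 3 (0.03 log units; within the scatter) each exchange the group at the same place on the shared core, and none of them leaves the scatter. Compound 4 `COc1cccc(-c2cc(C)c(Nc3ccnc(Nc4ccc(C#N)cc4)n3)c(C)c2)c1` alters that same group: methoxy in place of trifluoromethyl on an aromatic carbon. Since the three measured exchanges at this place moved nothing beyond the scatter, no step beyond the scatter is expected for this one either, a 1.0-fold higher number from compound 1 to compound 4 (0.01 log units; within the scatter). Compound 4 is accordingly estimated at 4100 nM, with a range from 2000 nM to 8500 nM.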

Compound 4, half-maximal cytotoxic concentration: 2990 nM
Compound 4: the middle estimate sits 1.4-fold (0.14 log units) above what was measured; the range from low to high includes it.
By their numbers in this assay, from the lowest: compounds 4, 3, 1 and 2 (each within the scatter of the next).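

In this assay the exchange of trifluoromethyl for methoxy stays within the scatter (a 1.3-fold lower number from compound 1 to compound 4 (0.13 log units; within the scatter)), and so do the steps to compound 4 from the other two compounds (a 1.3-fold lower number from compound 3 to compound 4 (0.13 log units; within the scatter); a 1.4-fold lower number from compound 2 to compound 4 (0.16 log units; within the scatter)). Methoxy brings a hydrogen-bond acceptor that trifluoromethyl lacks, yet on this read-out compound 4 cannot be told apart from the earlier compounds. No available measurement bears on this result.

The compounds shown leave open whether an amine or a carboxylic acid at this place would leave the scatter. The same holds for a longer chain, such as ethoxy in place of methoxy.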